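The source may hold more compounds than are shown below. What is called first, only, known or untested is meant among the compounds shown, and "the series" means these compounds.

Of the compounds shown here, three sharing one core have been tested in a functional assay on spleen for antagonist activity at Alpha-1B adrenergic receptor (Rattus norvegicus); a lower number here means a less potent compound, a higher number a more potent compound, by a factor of ten per unit of this negative logarithm. Compound 1, `COc1cccc(OC)c1OCCNCCOc1ccccc1OCc1ccccc1Cl`, gives 7.52. Compound 2, `COc1cccc(OC)c1OCCNCCOc1ccccc1OCc1cccc(Cl)c1`, gives 7.93. Compound 3, `COc1cccc(OC)c1OCCNCCOc1ccccc1OCc1ccccc1C`, gives 7.67. The value of compound 3 lies within the usual scatter of both neighbours: the difference a number 0.15 log units higher from compound 1 to compound 3 (within the scatter) and the difference a number 0.26 log units lower from compound 2 to compound 3 (within the scatter) are each too small to count as a real change.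

The next compound, compound 4, is `COc1cccc(OC)c1OCCNCCOc1ccccc1OCc1cccc(C)c1`. It differs from compound 3 by 3-methylphenyl in place of 2-methylphenyl on a saturated chain carbon bound to an oxygen on an aromatic ring. The same kind of move has been seen once before: the step of a number 0.41 log units higher from compound 1 to compound 2 (beyond the scatter), in which a chloro substituent on the benzyl ring was shifted from the 2-position to the 3-position, was beyond the scatter and raised the number. Going by the values given here, whether a methyl group behaves the same way is not known from these compounds; only one pair shows the 2-to-3 shift at all, and it involves a different group. Still, this single step is the closest guide available. Compound 4 is therefore expected to be somewhat more potent than compound 3, with a step of about a number 0.30 log units higher from compound 3 to compound 4 (within the scatter). The estimate for compound 4 in this assay is 7.97, with a likely range from 7.6 to 8.35.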

Compound 4, negative logarithm of the antagonist equilibrium constant: 8.2
Compound 4: middle estimate off by 0.23 log units, on the low side; measured number inside the range.
By their numbers in this assay, from the lowest: compounds 1, 3, 2 and 4 (each within the scatter of the next, the first and the last beyond it).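

In this assay, the shift from 2-methylbenzyl to 3-methylbenzyl gives a number 0.53 log units higher from compound 3 to compound 4 (beyond the scatter). The gain seen with chloro, a number 0.41 log units higher from compound 1 to compound 2 (beyond the scatter), therefore now appears with a second group, so two pairs of compounds, rather than one, favour the 3-substituted benzyl ring over the 2-substituted one. Changing both the place and the group gives a number 0.68 log units higher from compound 1 to compound 4 (beyond the scatter), while a number 0.27 log units higher from compound 2 to compound 4 (within the scatter) leaves those two compounds indistinguishable, and the methyl-for-chloro swap shows no real effect at either place on the ring: the same change on two cores in this assay, a number 0.15 log units higher (within the scatter) from compound 1 to compound 3 and a number 0.27 log units higher (within the scatter) from compound 2 to compound 4, 0.12 log units apart, within the scatter of two such steps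

Without the plain, unsubstituted benzyl group as a reference, these compounds cannot show whether the 3-substituent raises the number, the 2-substituent lowers it, or both are true. Whether a trifluoromethyl, a methoxy or an amine group on the benzyl ring would follow the same trend also remains open, since chloro and methyl are the only two groups shown there.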